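This account rests on a few compounds, and the source may have more. Where it says the series, first, only, none or still open, it means among the compounds named here.

In an assay (Canis lupus familiaris) for binding affinity to platelet-activating factor receptor (Homo sapiens), read by radioligand binding (a lower number here means a stronger inhibitor, a higher number a weaker inhibitor), compound 1 `C=CCc1cc(C(=O)N[C@H](C)CCCc2cccnc2)ccc1-c1ccc(OC)c(OC)c1` gives 80 nM. Compound 3 `COc1ccc(-c2ccc(C(S)=N[C@H](C)CCCc3cccnc3)cc2)cc1OC` gives 60 nM in this assay, a number within the scatter of compound 1. Compound 2 `O=C(NCCCCc1cccnc1)c1ccc(-c2cccc(O)c2)cc1` gives 300 nM in this assay, the highest of the three numbers and beyond the scatter from compound 1, which thus stands second highest of the three. Compound 4 `CCc1cc(C(=O)N[C@H](C)CCCc2cccnc2)ccc1-c1ccc(OC)c(OC)c1` has not been measured. It differs from compound 1 in one place: methyl in place of vinyl on a saturated chain carbon bound to an aromatic carbon. Going by the values given here, no measured pair shows this change, so its effect is unknown. The move from allyl to ethyl is expected to give a step in this assay no larger than the scatter, and a 1.3-fold higher number from compound 1 to compound 4 (0.10 log units; within the scatter) is the step expected. Compound 4 is therefore estimated at 100 nM, between 40 nM and 250 nM.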

Compound 4, half-maximal inhibitory concentration: 4 nM
Compound 4: the middle estimate sits 25-fold (1.40 log units) above what was measured; measured number outside the range, below it.
By their numbers in this assay, from the lowest: compound 4; then compounds 3 and 1 (each within the scatter of the next); then compound 2.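

In this assay, the change from allyl to ethyl on a saturated chain carbon bound to an aromatic carbon gives a 20-fold lower number from compound 1 to compound 4 (1.30 log units; beyond the scatter) and so shows that this position on the core of compound 1 strongly affects the number. The earlier compounds shown here offered no pair that could show this, and the change removes only the vinyl and brings in methyl. Nothing available explains why the step is so large. Going by these compounds, it remains open whether a propyl chain, a cyclopropyl group or a hydrogen at this place would keep the low number. It is also open whether the same change would have a comparable effect on the other cores shown.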